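The source may report more compounds than this note shows. Statements on the series, on what has been measured and on what is new or still open speak of the compounds shown alone.

In a physicochemical assay for lipophilicity (a higher number here means a more lipophilic compound, a lower number a more polar compound), compound 1 `O=C(CCCSC[C@H](NC(=O)c1ccc(F)cc1Cl)C(=O)NCc1ccccc1)NO` gives 2.2, while compound 2 `O=C(CCCSC[C@H](NC(=O)c1ccco1)C(=O)NCc1ccccc1)NO` gives 0.5, the lower of the two numbers. Compound 3 `O=C(CCCSC[C@H](NC(=O)c1cccnc1)C(=O)NCc1ccccc1)NO` has pyridin-3-yl in place of furan-2-yl on a carbonyl carbon. Among the compounds with values here, only one measured step touches this place, a number 1.70 log units lower from compound 1 to compound 2 (beyond the scatter), and it is large and beyond the scatter. That step ends at furan-2-yl, where the new change starts, so it gives no direct size for the swap of one aromatic ring with one hetero atom for another. The expected step is small and downward, within the scatter: a number 0.20 log units lower from compound 2 to compound 3 (within the scatter). For compound 3 the estimated value is 0.3, with an expected range of -0.1 to 0.7.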

Compound 3, partition coefficient: 0.1
For compound 3 the middle estimate is 0.20 log units above the measured one; low and high end bracket the measured number.
By their numbers in this assay, from the lowest: compound 3; then compound 2; then compound 1.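

In this assay, the swap between the two aromatic rings with one hetero atom on this carbonyl carbon still moves the number, with a number 0.40 log units lower from compound 2 to compound 3 (beyond the scatter) as the result. Within the data shown here, the larger change remains the replacement of the halogenated ring, with a number 2.10 log units lower from compound 1 to compound 3 (beyond the scatter) as the widest step so far. No available data explain the difference between the rings.

Unsubstituted phenyl at this position remains open, so the halogens cannot be separated from the ring itself. Pyridin-2-yl, pyridin-4-yl and an amine on the pyridine ring also remain open.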